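A few compounds are considered here, and "the series" means these few. Any claim that something is new, unique, unknown or untested is made for them only; others in the source may bear on it.

Going by the values given here, in a functional assay on L929 cells (Mus musculus) for antiproliferative activity, read by MTT assay (a higher number here means a weaker inhibitor, a lower number a stronger inhibitor), compound 1 `O=C1C2C(O)CCCC2[C@H]2[C@@H]1CC(Br)C21OCCO1` gives 22 ug/mL, the only actual number so far. Compound 2 `CC(C)(C)[Si](O[C@H]1C[C@H]2CC(=O)C[C@H]2C1)(c1ccccc1)c1ccccc1`, which also carries silicon on an oxygen, gives > 40 ug/mL, which is a limit of the assay and not a number. These two compounds differ in many places, so they do not isolate any single structural change. Compound 3 `CC(C)(C)[Si](C)(C)OC1CCCC2C1C(=O)[C@H]1CC(Br)C3(OCCO3)[C@@H]21` keeps the core of compound 1 and changes it in one place: a group of 7 heavy atoms (6 carbon, 1 silicon; no ring) in place of a hydrogen atom, on an oxygen on a saturated carbon. Among the compounds with values here, no measured step shows what such a swap does here, so compound 1 at 22 ug/mL is the natural starting point. No step beyond the usual scatter is expected, and the estimated change is a 1.3-fold higher number from compound 1 to compound 3 (0.10 log units; within the scatter). For compound 3 the expected value is 28 ug/mL, with an estimated range from 11 ug/mL to 60 ug/mL.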

Compound 3, half-maximal inhibitory concentration: 32 ug/mL
For compound 3 the middle estimate is 1.1-fold (0.06 log units) below the measured one, and the stated range covers the measured number.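

In this assay, a group of 7 heavy atoms (6 carbon, 1 silicon; no ring) in place of a hydrogen atom, on an oxygen on a saturated carbon, gives a 1.5-fold higher number from compound 1 to compound 3 (0.16 log units; within the scatter). Going by these compounds alone, this is the first step that can be read at this position, and it shows that the hydrogen atom on this oxygen can be swapped for this group with no change beyond the usual scatter. Compound 2 adds nothing to this step, since its value is a limit of the assay and not a number: the limit of > 40 ug/mL in this assay, at which 1 of the 3 values shown sits.

Going by these compounds, it remains open whether a methyl or an acetyl group on this same oxygen would behave the same way. The compounds shown hold only this one step, so they also say nothing about a change elsewhere on the core of compound 1, such as an amine in place of the bromine.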